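A few compounds are considered here, and "the series" means these few. Any claim that something is new, unique, unknown or untested is made for them only; others in the source may bear on it.

Compound 1: `COc1ccc(-c2cc(=O)c3c(OC)cc(OC)cc3n2S(=O)(=O)c2ccc(C=O)cc2)cc1`, > 34400 nM
Compound 2: `COc1ccc(-c2cc(=O)c3c(OC)cc(OC)cc3n2S(=O)(=O)c2cccc([N+](=O)[O-])c2)cc1`, > 39600 nM

In an ADME assay on BJ cells (Homo sapiens) for antiproliferative activity, with a stated time of 72 h (a lower number here means that less compound is needed, a higher number that more compound is needed for the effect), compound 1 gives > 34400 nM, which is a limit and not a number. Compound 2 gives > 39600 nM, which is also a limit. Compound 2 therefore has no exact position on the scale, and the only other measured result is a limit as well.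

The next compound, compound 3 (`COc1ccc(-c2cc(=O)c3c(OC)cc(OC)cc3n2S(=O)(=O)c2cc(F)c(F)c(F)c2)cc1`), has not yet been measured. It differs from compound 2 in one place: 3,4,5-trifluorophenyl in place of 3-nitrophenyl on a sulfonyl sulfur. In words, it carries 3,4,5-trifluorophenyl in place of 3-nitrophenyl on a sulfonyl sulfur.

Among the measured compounds shown here, only one measured step bears on this change, since it too alters the group on the sulfonyl sulfur: a step that the two limits leave unreadable from compound 1 to compound 2. That step supplies no size to carry over. Neither measured compound gives a numerical reading, so no step beyond the usual scatter is expected in this assay, in either direction, and another limit is the likely outcome. The expected change is a step that the limit leaves unreadable from compound 2 to compound 3. For compound 3, the estimated value is 40000 nM, with an expected range from 15000 nM to 80000 nM.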

Compound 3, half-maximal effective concentration: > 65500 nM
Compound 3: a limit, no number; the forecaster's own chance of this, stated with the estimate: 80%; middle value at least 1.6-fold (0.21 log units) from the limit.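

In this assay compound 3 gives > 65500 nM, which is a limit and not a number. All three results are limits, so neither the step from compound 2 to compound 3 nor the step from compound 1 to compound 3 can be read. The compounds shown leave open whether changing the group on the sulfonyl sulfur alters the concentration needed for the effect.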